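The source may report more compounds than this note shows. Statements on the series, on what has been measured and on what is new or still open speak of the compounds shown alone.

Measured so far:
- compound 1 `O[C@H]1Cc2ccccc2C1NC1CCN(CCCc2c[nH]c3ccc(-n4cnnc4)cc23)CC1`: in an assay on CHO cells for displacement of a labelled ligand from 5-hydroxytryptamine receptor 1B (Homo sapiens) (a lower number here means a stronger inhibitor, a higher number a weaker inhibitor), compound 1 gives 300 nM
- compound 2 `c1ccc(CNCC2CCN(CCCc3c[nH]c4ccc(-n5cnnc5)cc34)CC2)cc1`: in this assay compound 2 gives 28 nM
- compound 3 `c1ccc(C2CCCCN2C2CCN(CCCc3c[nH]c4ccc(-n5cnnc5)cc34)CC2)cc1`: in this assay compound 3 gives 410 nM

Compound 1 stands second highest of the three numbers. Its nearest neighbour is compound 3, and the two values lie within the scatter of each other, so no order between them can be read. Going by the values given here, the furthest is compound 2, reached by the one step of the set: an 11-fold lower number from compound 1 to compound 2 (1.03 log units; beyond the scatter).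

Compound 4 `CN(C1CCN(CCCc2c[nH]c3ccc(-n4cnnc4)cc23)CC1)S(=O)(=O)c1ccccc1` is obtained from compound 1 by methyl(phenylsulfonyl)amino in place of (2-hydroxy-2,3-dihydro-1H-inden-1-yl)amino on a saturated ring carbon. The step bearing on this is an 11-fold lower number from compound 1 to compound 2 (1.03 log units; beyond the scatter), where the same group left the same saturated ring carbon and another amine entered; compound 3, which carries yet another substituent on that carbon, gives a value close to compound 1. Among the compounds with values here, no measured compound carries the methyl(phenylsulfonyl)amino group, so there is no direct precedent for it in this assay. One replacement at this carbon gave a large lowering, another left the number essentially unchanged; a moderate lowering, if any, is expected here, with a wide range. For compound 4 the estimate in this assay is 150 nM, between 40 nM and 600 nM, which is expected to amount to a 2.0-fold lower number from compound 1 to compound 4 (0.30 log units; within the scatter).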

Compound 4, half-maximal inhibitory concentration: 10 nM
For compound 4 the middle estimate is 15-fold (1.18 log units) above the measured one; the measured number lies below the stated range.
By their numbers in this assay, from the lowest: compound 4; then compound 2; then compounds 1 and 3 (each within the scatter of the next).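

In this assay the saturated ring carbon, three ring bonds from the ring nitrogen, tolerates more than the earlier amines suggested: methyl(phenylsulfonyl)amino in place of (2-hydroxy-2,3-dihydro-1H-inden-1-yl)amino gives a large change (a 30-fold lower number from compound 1 to compound 4 (1.48 log units; beyond the scatter)). The same group also improves on the best earlier substituent, (benzylamino)methyl, by a modest step that is still beyond the scatter (a 2.8-fold lower number from compound 2 to compound 4 (0.45 log units; beyond the scatter)), so the lowest number of the set at this position belongs to a group with 0 hydrogen-bond donors, against 2 in the group that left. No measurement on hand accounts for these steps.

As far as these compounds go, it remains open which part of the entering group carries the change: a carboxamide in place of the sulfonyl, hydrogen in place of the methyl on the nitrogen, or a fluorine or methoxy substituent on the phenyl ring could each separate these contributions. From the compounds shown here alone, it is also open whether the sulfonamide keeps its advantage when the propyl chain or the triazole of the shared core is replaced, for example by a longer chain or an amide.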